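From 3-methoxyphenyl to 3-bromophenyl: notes on compound 3

The source may hold more compounds than are shown below. What is called first, only, known or untested is meant among the compounds shown, and "the series" means these compounds.

In a functional assay on HT-29 cells (Homo sapiens) for antiproliferative activity, read by sulforhodamine B assay, with a stated time of 48 h (on this read-out higher numbers stand for weaker inhibition and lower numbers for stronger inhibition), compound 1 `CCCCN1CCN(c2ccc(S(=O)(=O)Oc3ccccc3)cc2)C1=O` gives > 100000 nM as a limit of the assay, not a number. Among the compounds with values here, compound 2 `CCCCN1CCN(c2ccc(S(=O)(=O)Oc3cccc(OC)c3)cc2)C1=O` gives 13000 nM as the only number so far. Within the data shown here, the step of an at least 7.6-fold lower number from compound 1 to compound 2 (0.88 log units; beyond the scatter) lies beyond the scatter and is the only measured step that bears on this place. Among the measured compounds shown here, compound 3 `CCCCN1CCN(c2ccc(S(=O)(=O)Oc3cccc(Br)c3)cc2)C1=O` carries bromo in place of methoxy on an aromatic carbon and no measured step covers that exchange. In this assay no step beyond the scatter is expected in either direction. The expected step of a 1.3-fold lower number from compound 2 to compound 3 (0.11 log units; within the scatter) is therefore small. For compound 3 the expected value is 10000 nM with an estimated range from 3000 nM to 40000 nM in this assay.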

Compound 3, half-maximal inhibitory concentration: 16000 nM
The estimate for compound 3 lay 1.6-fold (0.20 log units) below the measured number; the measured number falls inside the stated range.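

In this assay, the exchange of methoxy for bromo on this aromatic carbon leaves the number unchanged within the scatter: a 1.2-fold higher number from compound 2 to compound 3 (0.09 log units; within the scatter). Bromo in place of hydrogen gives an at least 6.2-fold lower number from compound 1 to compound 3 (0.79 log units; beyond the scatter), so the lower number at this position is not tied to methoxy alone. Compound 1 stands at a limit of the assay, not a number, so that step gives only a bound on the size: the limit of > 100000 nM in this assay, at which 1 of the 3 values shown sits.

From the compounds shown here alone, what an amine or a carboxylic acid at this place would give stays open. So does whether a longer chain in place of methoxy would keep the number.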